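The compounds below may be only part of what the source reports. "The series", "measured", "known", "first", "only" and "open" are said of these compounds alone.

Measured compounds:
- compound 1 `COc1ccc(-c2ccc3c(c2)C(=O)C(=O)N3Cc2ccccc2Cl)cc1`; in a functional assay on HepG2 cells (Homo sapiens) for antiproliferative activity, read by MTT assay, with a stated time of 48 h (on this read-out higher numbers stand for weaker inhibition and lower numbers for stronger inhibition), compound 1 gives 600 nM
- compound 2 `COc1ccc(CN2C(=O)C(=O)c3cc(-c4ccc(OC)cc4)ccc32)cc1`; in this assay compound 2 gives 50 nM
- compound 3 `COc1ccc(-c2ccc3c(c2)C(=O)C(=O)N3Cc2cccc(OC)c2)cc1`; in this assay compound 3 gives 700 nM

Compound 2 holds the lowest number of the three in this assay. The step of a 12-fold lower number from compound 1 to compound 2 (1.08 log units; beyond the scatter) and the step of a 14-fold higher number from compound 2 to compound 3 (1.15 log units; beyond the scatter) both lie beyond the scatter, so compound 2 is the strongest inhibitor among the measured compounds, while compound 1 and compound 3 sit together, as a 1.2-fold higher number from compound 1 to compound 3 (0.07 log units; within the scatter) shows.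

Compound 4 `COc1ccc(CN2C(=O)C(=O)c3cc(-c4ccc(C#N)cc4)ccc32)cc1` keeps the 4-methoxyphenyl on the saturated chain carbon bound to the amide-type nitrogen, the group that set compound 2 apart, and changes the other end of the shared core instead: cyano in place of methoxy on an aromatic carbon. Among the compounds with values here, no measured step touches this aromatic carbon; every measured step concerns the group on the saturated chain carbon. The measured steps therefore give no direct guide, and only a modest change is expected for compound 4 in this assay, a 2.0-fold higher number from compound 2 to compound 4 (0.30 log units; within the scatter). Compound 4 is estimated at 100 nM, within a range of 30 nM to 400 nM.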

Compound 4, half-maximal inhibitory concentration: 890 nM
Estimate against measurement, compound 4: 8.9-fold (0.95 log units) below; the measured number lies above the stated range.
By their numbers in this assay, from the lowest: compound 2; then compounds 1, 3 and 4 (each within the scatter of the next).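

The aromatic carbon that every earlier compound left as methoxy turns out to matter in this assay: with the 4-methoxyphenyl on the chain carbon held fixed, cyano in place of methoxy gives an 18-fold higher number from compound 2 to compound 4 (1.25 log units; beyond the scatter). This step lies beyond the scatter, so the number depends on this end of the shared core as well as on the group on the saturated chain carbon, even though the two groups have the same count of heavy atoms and of hydrogen-bond acceptors. No measurement shown here accounts for the difference between methoxy and cyano at this carbon.

The compounds shown leave open whether another group on this carbon, such as an amine, a carboxylic acid or a longer alkoxy chain, would stay near compound 2 in this assay. They also leave open whether cyano would bring a similar step with 2-chlorophenyl or 3-methoxyphenyl on the chain carbon.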